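A few compounds are considered here, and "the series" means these few. Any claim that something is new, unique, unknown or untested is made for them only; others in the source may bear on it.

Compound 1 `CC(C)Sc1nnc(-c2c(CNCCN3CCCC3)c3cc(F)ccc3n2C)n1-c1ccccc1` gives 4.99 in a physicochemical assay for lipophilicity; a higher number here means a more lipophilic compound, a lower number a more polar compound. Compound 2 `CC(C)Sc1nnc(-c2c(CNC3CC3)c3ccccc3n2C)n1-c1ccccc1` gives 4.81, and compound 3 `CC(C)Sc1nnc(-c2c(CNCC3CC3)c3ccccc3n2C)n1-c1ccccc1` gives 5.24. Compound 1 thus stands second highest of the three, with compound 2 and compound 3 both within the scatter of it. Among the measured compounds shown here, the one measured step, a number 0.43 log units higher from compound 2 to compound 3 (beyond the scatter), concerns a different change on the amine nitrogen and offers only indirect guidance. Compound 4 `COCCNCc1c(-c2nnc(SC(C)C)n2-c2ccccc2)n(C)c2ccc(F)cc12` differs from compound 1 by methoxy in place of pyrrolidin-1-yl on a saturated chain carbon, two bonds along the chain from an amine nitrogen. A smaller group with fewer heavy atoms enters, so a modest downward step is expected, estimated as a number 0.59 log units lower from compound 1 to compound 4 (beyond the scatter). Compound 4 is therefore expected to give about 4.4, most likely between 3.8 and 5.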

Compound 4, partition coefficient: 4.52
Compound 4: middle estimate off by 0.12 log units, on the low side; the measured number falls inside the stated range.
By their numbers in this assay, from the lowest: compounds 4, 2, 1 and 3 (each within the scatter of the next, the first and the last beyond it).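

In this assay, methoxy in place of pyrrolidin-1-yl on a saturated chain carbon, two bonds along the chain from an amine nitrogen, gives a number 0.47 log units lower from compound 1 to compound 4 (beyond the scatter) on an otherwise unchanged structure. This pair shows that a change at this position alone can move the number beyond the scatter, which the earlier step on the amine nitrogen could not show. Nothing measured here explains the size of this step. From the compounds shown here alone, it remains open whether a morpholin-4-yl or a hydroxy group at the same place would give a number closer to compound 1 or to compound 4.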